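Does a benzyl ester change the cytotoxicity read-out?

A few compounds are considered here, and "the series" means these few. Any claim that something is new, unique, unknown or untested is made for them only; others in the source may bear on it.

Compound 1 `COc1ccc(-c2cc3c(OC)cc(OC)cc3n(CCCC#N)c2=O)cc1`: 10000 nM
Compound 2 `COC(=O)CCn1c(=O)c(-c2ccc(OC)cc2)cc2c(OC)cc(OC)cc21`: 10000 nM

In a functional assay on U-373MG ATCC cells for cytotoxicity against U373 MG (Homo sapiens), read by colorimetric assay and MTT assay (on this read-out lower numbers stand for stronger inhibition and higher numbers for weaker inhibition), compound 2 gives 10000 nM, level with compound 1 at 10000 nM. Compound 3 `COc1ccc(-c2cc3c(OC)cc(OC)cc3n(CCC(=O)OCc3ccccc3)c2=O)cc1` has not yet been measured. It differs from compound 2 by phenyl in place of hydrogen on a saturated chain carbon bound to an oxygen next to a carbonyl group, which turns methoxycarbonyl into benzyloxycarbonyl. Going by the values given here, the only measured step, no change at the digits printed from compound 1 to compound 2 (within the scatter), put methoxycarbonyl in place of cyanomethyl and stayed within the scatter. Among the compounds with values here, no measured compound tests an added phenyl, so the evidence is thin. The expected step in this assay is no change at the digits printed from compound 2 to compound 3 (within the scatter), with nothing beyond the scatter anticipated. For compound 3 the estimate is 10000 nM, with an expected range of 4000 nM to 20000 nM.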

Compound 3, half-maximal inhibitory concentration: 10000 nM
Estimate against measurement, compound 3: no gap at the digits printed; the measured number falls inside the stated range.
By their numbers in this assay, from the lowest: compounds 1, 2 and 3 (each within the scatter of the next).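

In this assay, putting phenyl on the ester's methyl gives no change at the digits printed from compound 2 to compound 3 (within the scatter), so a much larger ester group at this position leaves the read-out where it was. Replacing cyanomethyl with benzyloxycarbonyl likewise gives no change at the digits printed from compound 1 to compound 3 (within the scatter). No available data offer an explanation for this result.

Still open, from the compounds shown here alone, is whether a carboxylic acid or an amine in place of the ester, or a longer chain, would move the number. With all three compounds level, these data also cannot say which parts of the shared core matter for the read-out.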